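A few compounds are considered here, and "the series" means these few. Any claim that something is new, unique, unknown or untested is made for them only; others in the source may bear on it.

For the measured compounds named here, compound 2 `N#CC1=C(N)Oc2c(c3nc4ccccc4nc3c3ccccc23)C12C(=O)N(Cc1cnnn1-c1ccc([N+](=O)[O-])cc1)c1ccccc12` is one of the two compounds so far tested in a functional assay on HCT-116 cells (Homo sapiens) for antiproliferative activity, read by MTT assay, with a stated time of 48 h; on this read-out higher numbers stand for weaker inhibition and lower numbers for stronger inhibition. In this assay compound 2 gives > 50000 nM, which is a limit of the assay and not a number. Its closest neighbour, compound 1 `Cc1ccccc1-n1nncc1CN1C(=O)C2(C(C#N)=C(N)Oc3c2c2nc4ccccc4nc2c2ccccc32)c2ccccc21`, differs only in the group carried on the aromatic nitrogen, and in this assay compound 1 gives > 50000 nM, again a limit. The step that the two limits leave unreadable from compound 1 to compound 2 therefore cannot be read, since the limit of > 50000 nM in this assay, at which 2 of the 2 values shown sit, covers both values. Compound 3 `Cc1ccc(-n2nncc2CN2C(=O)C3(C(C#N)=C(N)Oc4c3c3nc5ccccc5nc3c3ccccc43)c3ccccc32)c(C)c1` has not yet been measured, and it differs from compound 2 in one place: 2,4-dimethylphenyl in place of 4-nitrophenyl on an aromatic nitrogen. Going by the values given here, the only measured step that bears on this change, a step that the two limits leave unreadable from compound 1 to compound 2, shows nothing that can be sized, so no step beyond the scatter can be foreseen in this assay in either direction. The step that the limit leaves unreadable from compound 2 to compound 3 that the estimate implies is expected to stay within the scatter. On that basis compound 3 is expected to give about 60000 nM in this assay, within a range from 20000 nM to 200000 nM, and most probably once more only as a limit.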

Compound 3, half-maximal inhibitory concentration: > 50000 nM
Compound 3 was reported as a limit (the forecaster's own chance of this, stated with the estimate: 80%); the middle value is on the limit's open side.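

No step can be read between compound 1, compound 2 and compound 3 in this assay, since all three values are limits of the assay and not numbers: the limit of > 50000 nM in this assay, at which 3 of the 3 values shown sit.

The compounds shown leave open whether the 2-methylphenyl, 4-nitrophenyl and 2,4-dimethylphenyl groups on the aromatic nitrogen differ at all in this assay, and which compound of this kind would give a readable value.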